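Extending a Side Group and Its Expected Cell Toxicity

A few compounds are considered here, and "the series" means these few. Any claim that something is new, unique, unknown or untested is made for them only; others in the source may bear on it.

Compound 1 `CC(C)(NC(=O)c1ccc([N+](=O)[O-])o1)c1ccc(Cl)cc1` and compound 2 `O=C(NCc1ccc(-c2ccc(Cl)cc2)cc1)c1ccc([N+](=O)[O-])o1` share a common core and were both tested in an ADME assay on Vero cells (Chlorocebus sabaeus) for cytotoxicity, read by MTT assay, with a stated time of 48 h; on this read-out lower numbers stand for higher toxicity in this test and higher numbers for lower toxicity in this test. Compound 1 gives 81000 nM, the higher of the two numbers and therefore the less toxic of the pair, while compound 2 gives 4400 nM, a gap well beyond the scatter. Compound 3 `CC(C)(NC(=O)c1ccc([N+](=O)[O-])o1)c1ccc(COc2ccccc2Cl)cc1` has not yet been measured. It differs from compound 1 in one place: (2-chlorophenoxy)methyl in place of chloro on an aromatic carbon. Going by the values given here, the only comparison available, between compound 1 and compound 2, shows that the compound carrying the extended aromatic side group gives the lower number. On that basis a downward step from compound 1, beyond the scatter, is expected, with the result estimated at a 5.4-fold lower number from compound 1 to compound 3 (0.73 log units; beyond the scatter). In this assay compound 3 is therefore expected to give 15000 nM, with a range from 4000 nM to 50000 nM.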

Compound 3, half-maximal cytotoxic concentration: 30000 nM
Compound 3: middle estimate off by 2.0-fold (0.30 log units), on the low side; low and high end bracket the measured number.
By their numbers in this assay, from the lowest: compound 2; then compound 3; then compound 1.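

In this assay, putting (2-chlorophenoxy)methyl in place of chloro on this aromatic carbon, para to a large group, gives a 2.7-fold lower number from compound 1 to compound 3 (0.43 log units; beyond the scatter), a modest step but one beyond the usual scatter. Going by these compounds alone, this is the first direct look at this position: with the rest of compound 1 unchanged, the much larger group, with its extra aromatic ring and hydrogen-bond acceptor, does lower the number, so toxicity in this test rises, though only modestly. No measurement here explains why the number moves.

The compounds shown leave open which part of the new group matters: the added ring, its oxygen or its chlorine. Also open, as far as these compounds go, is how a different kind of group at this position, such as an amine or a carboxylic acid, would shift the number.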